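Shifting the Chlorine on the Chlorophenyl Ring

This account rests on a few compounds, and the source may have more. Where it says the series, first, only, none or still open, it means among the compounds named here.

Compound 1 `Oc1cccc(-c2cc(-c3cccnc3)nc(-c3cccc(Cl)c3)c2)c1` gives 27.6% in an assay on isolated protein for inhibition of DNA topoisomerase 1 (Homo sapiens), with a stated time of 30 min, tested at 100 uM; on this read-out higher numbers stand for a stronger effect at the one concentration tested and lower numbers for a weaker effect. Compound 2 `Oc1cccc(-c2cc(-c3ccc(Cl)cc3)nc(-c3cccnc3)c2)c1` gives 2.8%, and compound 3 `Oc1ccc(-c2cc(-c3ccc(Cl)cc3)nc(-c3ccco3)c2)cc1` gives 15.8%. The change from compound 2 to compound 1 is 3-chlorophenyl in place of 4-chlorophenyl on an aromatic carbon, and it brought a number 24.8 percentage points higher from compound 2 to compound 1 (beyond the scatter). The difference between the cores of compound 2 and compound 3 is not broken down here.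

Compound 4 `Oc1ccc(-c2cc(-c3cccc(Cl)c3)nc(-c3ccco3)c2)cc1` is not yet measured. It arises from compound 3 by 3-chlorophenyl in place of 4-chlorophenyl on an aromatic carbon, the same kind of change as from compound 2 to compound 1, but here meta to a 4-hydroxyphenyl group and meta to a furan-2-yl group rather than meta to a 3-hydroxyphenyl group and a pyridin-3-yl group. For the measured compounds named here, because the only precedent, a number 24.8 percentage points higher from compound 2 to compound 1 (beyond the scatter), sits on a different core, a smaller gain is expected, a number 12.2 percentage points higher from compound 3 to compound 4 (beyond the scatter). Compound 4 is estimated at 28%, between 10% and 50%.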

Compound 4, a percentage reported as inhibition, at one concentration (the size of the read-out at that concentration, not a potency): 25.5%
For compound 4 the middle estimate is 2.5 percentage points above the measured one; the measured number falls inside the stated range.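

In this assay, 3-chlorophenyl in place of 4-chlorophenyl on the core of compound 3 brought a number 9.7 percentage points higher from compound 3 to compound 4 (within the scatter), so on this core the change has no clear effect. The change did not carry over at the same size from one core to the other: the same change on two cores in this assay, a number 24.8 percentage points higher (beyond the scatter) from compound 2 to compound 1 and a number 9.7 percentage points higher (within the scatter) from compound 3 to compound 4, 15.1 percentage points apart, beyond the scatter of two such steps This shows that the size of the step depended on the core in these two pairs, but it does not show which difference between the cores accounts for that, and two pairs set no rule for the series.

The compounds shown leave open what an amine or a carboxylic acid in place of the chlorine would do on either core. Also open, going by these compounds, is whether a methoxy group in place of the hydroxyl would alter the step.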